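The compounds below may be only part of what the source reports. "The series", "measured", "known", "first", "only" and "open" are said of these compounds alone.

Two measured compounds share one core. Compound 1 `C/C(C#Cc1ccccc1)=N\N/C(N)=N/S(=O)(=O)c1cc(C)c(Cl)cc1SCc1cccc(C(F)(F)F)c1` in a functional assay on HCT-116 cells (Homo sapiens) for antiproliferative activity, read by MTT assay, with a stated time of 72 h (a higher number here means a weaker inhibitor, a lower number a stronger inhibitor), gives 14000 nM. Compound 2 `C/C(C#Cc1ccccc1)=N\N/C(N)=N/S(=O)(=O)c1cc(C)c(Cl)cc1SCc1cccc(Cl)c1` in this assay gives 119000 nM, the highest of the two numbers; the step of an 8.5-fold higher number from compound 1 to compound 2 (0.93 log units; beyond the scatter) arises from chloro in place of trifluoromethyl on an aromatic carbon. Compound 3 `C/C(C#Cc1ccccc1)=N\N/C(N)=N/S(=O)(=O)c1cc(C)c(Cl)cc1SCc1ccc(Cl)cc1` is not yet measured. It differs from compound 2 by 4-chlorophenyl in place of 3-chlorophenyl on a saturated chain carbon bound to a sulfur: the same atoms, joined differently, so the 3-chlorobenzyl becomes a 4-chlorobenzyl. Among the compounds with values here, no measured step moves the chlorine around that ring; the one step available, an 8.5-fold higher number from compound 1 to compound 2 (0.93 log units; beyond the scatter), only shows that exchanging the group on this ring shifts the number by a modest amount. Without a matching precedent, the expected step of a 1.2-fold lower number from compound 2 to compound 3 (0.08 log units; within the scatter) is set near no change, with wide uncertainty. The estimate for compound 3 in this assay is therefore 100000 nM, expected to fall between 25000 nM and 400000 nM.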

Compound 3, half-maximal inhibitory concentration: 10000 nM
For compound 3 the middle estimate is 10-fold (1.00 log units) above the measured one, outside the stated range (below it).
By their numbers in this assay, from the lowest: compounds 3 and 1 (each within the scatter of the next); then compound 2.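

Moving a single chlorine on the benzyl ring, with no atom gained or lost, is enough to matter in this assay (a 12-fold lower number from compound 2 to compound 3 (1.08 log units; beyond the scatter)), so where the group sits on this ring counts, and not only which group it is. The 4-chlorophenyl and 3-(trifluoromethyl)phenyl groups cannot be told apart here (a 1.4-fold lower number from compound 1 to compound 3 (0.15 log units; within the scatter)), so chlorine on this ring does not by itself give the high number of compound 2. Nothing measured here explains why the two chlorobenzyl isomers differ.

Still open, going by these compounds, is how a methoxy group, a nitrile or an amine would behave on this ring. On these data alone, it is also open whether a plain benzyl group with no substituent would fall near compound 2 or near compound 3.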